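The source may report more compounds than this note shows. Statements on the series, on what has been measured and on what is new or still open speak of the compounds shown alone.

Measured so far:
compound 1 `O=C(Nc1ccc(F)cc1F)c1ccccc1OCc1ccc(F)cc1F` with > 40000 nM; compound 2 `COc1ccc(C(=O)Nc2ccc(F)cc2F)c(OCc2ccc(F)cc2F)c1` with > 40000 nM; compound 3 `COc1ccccc1C(=O)Nc1ccc(I)cc1F` with > 40000 nM.

In an ADME assay on RAW264.7 cells (Mus musculus) for cytotoxicity, read by MTT assay, with a stated time of 24 h (a higher number here means that more compound is tolerated, a lower number that less compound is tolerated), compound 1 gives > 40000 nM, which is a limit of the assay. Compound 2 gives > 40000 nM, also a limit. Compound 3 gives > 40000 nM, again a limit, so all three sit at the limit of > 40000 nM in this assay, at which 3 of the 3 values shown sit. The change from compound 2 to compound 1 is hydrogen in place of methoxy on an aromatic carbon, and the step that the two limits leave unreadable from compound 2 to compound 1 cannot be read. How the core of compound 3 differs from that of compound 2 is not broken down here. Compound 4 `O=C(Nc1ccc(I)cc1F)c1ccccc1` is not yet measured; it arises from compound 3 by hydrogen in place of methoxy on an aromatic carbon, the same kind of change, though the place differs: ortho to a large group rather than meta to a large group and para to a large group. Because compound 3 gives > 40000 nM, compound 4 is expected to show a step of a number no higher from compound 3 to compound 4 (the limit leaves the size open) in this assay, so its estimated value is 40000 nM, between 15000 nM and 100000 nM, most likely again reported only as a limit.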

Compound 4, half-maximal cytotoxic concentration: > 40000 nM
Compound 4: only a limit was reported; the forecaster's own chance of this, stated with the estimate: 75%; the middle value lies on the limit itself.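

Among these compounds, compound 3 and compound 4 both stand at a limit of the assay, so no step between them can be read. The compounds shown leave open whether hydrogen in place of methoxy changes the tolerated concentration at all: the limit of > 40000 nM in this assay, at which 4 of the 4 values shown sit.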